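A few compounds are considered here, and "the series" means these few. Any claim that something is new, unique, unknown or untested is made for them only; others in the source may bear on it.

Measured so far:
compound 1 `COc1cc(Nc2nc3ccccc3nc2S(=O)(=O)c2ccccc2)cc(OC)c1`: 140 nM
compound 2 `Nc1ccc(Nc2nc3ccccc3nc2S(=O)(=O)c2ccccc2)cc1`: 5830 nM

Within the data shown here, in a functional assay on PC-3 cells (Homo sapiens) for cytotoxicity, read by MTT assay, with a stated time of 72 h (a higher number here means a weaker inhibitor, a lower number a stronger inhibitor), compound 1 stands lowest of the two numbers; compound 2 is the only neighbour, at a 42-fold higher number from compound 1 to compound 2 (1.62 log units; beyond the scatter). Compound 3 `O=S(=O)(c1ccccc1)c1nc2ccccc2nc1Nc1ccc(C(F)(F)F)cc1` is not yet measured. Among the measured compounds shown here, it differs from compound 1 in one place: 4-(trifluoromethyl)phenyl in place of 3,5-dimethoxyphenyl on a nitrogen on an aromatic ring The one measured step at this nitrogen, a 42-fold higher number from compound 1 to compound 2 (1.62 log units; beyond the scatter), was large and upward, but it brought in a different group, so it fixes direction more than size here. A rise beyond the scatter, smaller than that step, is expected. Compound 3 is expected at 700 nM, within 150 nM to 4000 nM. The estimated step is a 5.0-fold higher number from compound 1 to compound 3 (0.70 log units; beyond the scatter).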

Compound 3, half-maximal inhibitory concentration: 3550 nM
Beside the measured number, compound 3's estimate is 5.1-fold (0.71 log units) below it; the range from low to high includes it.
By their numbers in this assay, from the lowest: compound 1; then compounds 3 and 2 (each within the scatter of the next).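

In this assay, 4-(trifluoromethyl)phenyl in place of 3,5-dimethoxyphenyl on this nitrogen also gives a large rise (a 25-fold higher number from compound 1 to compound 3 (1.40 log units; beyond the scatter)), so 4-aminophenyl is no longer the only replacement that loses the low number of compound 1. Trifluoromethyl in place of amino on the aromatic carbon stays within the scatter (a 1.6-fold lower number from compound 2 to compound 3 (0.22 log units; within the scatter)), so this assay does not separate these two groups. Nothing measured here explains either result.

As far as these compounds go, whether the low number of compound 1 needs both methoxy groups remains open. Also open, from the compounds shown here alone, is how a ring carrying a single methoxy, a hydroxyl or a chlorine would read.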